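The compounds below may be only part of what the source reports. "The series", "measured", "known", "first", "only" and "open" are said of these compounds alone.

Compound 1, `COc1ccc(F)cc1CNCCCNc1ccnc2cc(Cc3ccc(F)cc3Cl)ccc12`: 23 10^-6 cm/s
Compound 2, `COc1ccc(F)cc1CNCCCNc1ccnc2cc(-c3cccc4ccccc34)ccc12`: 237 10^-6 cm/s
Compound 3, `COc1cccc(CNCCCNc2ccnc3cc(Cc4ccc(F)cc4Cl)ccc23)c1O`: 23 10^-6 cm/s

These three compounds were measured in an ADME assay for permeability, using PAMPA, with a stated time of 30 min, at pH 7.4; on this read-out higher numbers stand for higher permeability and lower numbers for lower permeability. Compound 4, `COc1cccc(CNCCCNc2ccnc3cc(-c4cccc5ccccc45)ccc23)c1O`, has not yet been measured there. Compound 4 differs from compound 3 by naphthalen-1-yl in place of 2-chloro-4-fluorobenzyl on an aromatic carbon. The same change is made from compound 1 to compound 2, (naphthalen-1-yl in place of 2-chloro-4-fluorobenzyl on an aromatic carbon), and there it gave a 10-fold higher number from compound 1 to compound 2 (1.01 log units; beyond the scatter). The two cores differ by 2-hydroxy-3-methoxyphenyl in place of 5-fluoro-2-methoxyphenyl on a saturated chain carbon bound to an amine nitrogen, a change that gave no change at the digits printed from compound 1 to compound 3 (within the scatter). In this assay compound 3 gives 23 10^-6 cm/s, level with compound 1 at 23 10^-6 cm/s. Compound 4 is expected to move by an 8.7-fold higher number from compound 3 to compound 4 (0.94 log units; beyond the scatter), because the same change gave a 10-fold higher number from compound 1 to compound 2 (1.01 log units; beyond the scatter) on a core that starts from the same number. Compound 4 is estimated at 200 10^-6 cm/s, most likely between 70 10^-6 cm/s and 450 10^-6 cm/s.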

Compound 4, apparent permeability: 237 10^-6 cm/s
Compound 4: the middle estimate sits 1.2-fold (0.07 log units) below what was measured, and the stated range covers the measured number.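

In this assay, naphthalen-1-yl in place of 2-chloro-4-fluorobenzyl gave a 10-fold higher number from compound 3 to compound 4 (1.01 log units; beyond the scatter), and the step carried over from one core to the other: the same change on two cores in this assay, a 10-fold higher number (1.01 log units; beyond the scatter) from compound 1 to compound 2 and a 10-fold higher number (1.01 log units; beyond the scatter) from compound 3 to compound 4, 1.0-fold (0.00 log units) apart, within the scatter of two such steps
Likewise, 2-hydroxy-3-methoxyphenyl in place of 5-fluoro-2-methoxyphenyl gave no change at the digits printed from compound 2 to compound 4 (within the scatter), and this absence of a step also held on both cores: the same change on two cores in this assay, no change at the digits printed (within the scatter) from compound 1 to compound 3 and no change at the digits printed (within the scatter) from compound 2 to compound 4, 1.0-fold (0.00 log units) apart, within the scatter of two such steps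
This shows that the two changes acted independently across these four compounds, but two cores cannot show that this holds elsewhere in the series, nor why the number moves.

The compounds shown leave open whether the same step would appear on a core with a longer chain. Also open, from the compounds shown here alone, is what a carboxylic acid or an amine would give on that aromatic carbon in place of naphthalen-1-yl.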